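Series notes: the step from compound 3 to compound 4

This account rests on a few compounds, and the source may have more. Where it says the series, first, only, none or still open, it means among the compounds named here.

In a functional assay on NCI/ADR-RES cells (Homo sapiens) for inhibition, read by sulforhodamine B assay, with a stated time of 48 h (on this read-out lower numbers stand for stronger inhibition of growth and higher numbers for weaker inhibition of growth), compound 1 `COc1ccc(/C=N/NC(=S)NC(C)(C)[C@H]2CC=C(C)CC2)cc1` gives 50400 nM. Compound 2 `CC1=CC[C@H](C(C)(C)NC(=S)N/N=C/c2ccc(O)cc2)CC1` reaches only the limit > 100000 nM in this assay. Compound 3 `CC1=CC[C@H](C(C)(C)NC(=S)N/N=C/c2ccc(F)cc2)CC1` likewise stops at the limit > 100000 nM. Compound 3 thus stands at the limit of > 100000 nM in this assay, at which 2 of the 3 values shown sit, with no number of its own. The step of an at least 1.9-fold higher number from compound 1 to compound 3 (0.29 log units; that floor lies within the scatter) and the step of an at least 1.9-fold higher number from compound 1 to compound 2 (0.29 log units; that floor lies within the scatter) both run to a floor that lies within the scatter; the step that the two limits leave unreadable from compound 2 to compound 3 cannot be read. Compound 4 `CC1=CC[C@H](C(C)(C)NC(=S)N/N=C/c2cccc(Cl)c2)CC1` carries 3-chlorophenyl in place of 4-fluorophenyl on a carbon with a double bond to nitrogen. Within the data shown here, no measured step involves a 3-chlorophenyl group; the change cannot be sized from the series, and the steps that bear on it end at the limit. Compound 4 is therefore expected near that limit, with an expected step of a number no higher from compound 3 to compound 4 (the limit leaves the size open) of no readable size. The estimate for compound 4 is 100000 nM, between 40000 nM and 250000 nM.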

Compound 4, concentration for total growth inhibition: > 100000 nM
Compound 4: only a limit was reported; the forecaster's own chance of this, stated with the estimate: 60%; the middle value sits exactly at the limit.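

With 3-chlorophenyl on this carbon, the series meets the limit again, now with chlorine in place of the fluorine of compound 3 and a differently named ring pattern, so this swap yields no number of its own: the limit of > 100000 nM in this assay, at which 3 of the 4 values shown sit.

Among these compounds, compound 1, with 4-methoxyphenyl, remains the only compound with a number, and the step is an at least 1.9-fold higher number from compound 1 to compound 4 (0.29 log units; that floor lies within the scatter). The steps from compound 2 and compound 3 to compound 4 cannot be read.

Open, as far as these compounds go, is whether, in this assay, an amine or a carboxylic acid on the aromatic ring would give a number clearly under the limit. From the compounds shown here alone, a longer alkoxy chain in place of the methoxy of compound 1 is equally open.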